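Ester to acid at the amide side chain of compound 2

The source may hold more compounds than are shown below. What is called first, only, known or untested is meant among the compounds shown, and "the series" means these compounds.

Measured so far:
- compound 1, `C#CCCOC(=O)c1ccc(C(CC)(CC)c2ccc(OCCC(O)(CC)CC)c(C)c2)n1CC`: 6030 nM
- compound 2, `CCOC(=O)CN(C)C(=O)c1ccc(C(CC)(CC)c2ccc(OCCC(O)(CC)CC)c(C)c2)n1CC`: 520 nM

Both compounds share the same core and were tested in an assay on cells for agonist activity at vitamin D3 receptor (Homo sapiens), with a stated time of 96 h; a lower number here means that less compound is needed, a higher number that more compound is needed for the effect. Among the measured compounds shown here, compound 2 holds the lower of the two numbers; the single step that separates them, a 12-fold lower number from compound 1 to compound 2 (1.06 log units; beyond the scatter), came from a change on the carbonyl carbon and is well beyond the scatter. Compound 3, `CCn1c(C(=O)N(C)CC(=O)O)ccc1C(CC)(CC)c1ccc(OCCC(O)(CC)CC)c(C)c1`, has not yet been measured. It differs from compound 2 in one place: hydrogen in place of ethyl on an oxygen next to a carbonyl group. For the measured compounds named here, no measured step touches that oxygen, so the step from compound 1 to compound 2 says nothing directly about it. Going by the values given here, with no guiding step, a small change is expected, a 1.3-fold higher number from compound 2 to compound 3 (0.13 log units; within the scatter), in either direction. Compound 3 is therefore estimated at 700 nM, within a range of 150 nM to 3500 nM.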

Compound 3, half-maximal effective concentration: 89 nM
For compound 3 the middle estimate is 7.9-fold (0.90 log units) above the measured one; the whole stated range lies above it.
By their numbers in this assay, from the lowest: compound 3; then compound 2; then compound 1.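

Replacing ethyl with hydrogen on an oxygen next to a carbonyl group turns ethoxycarbonyl into carboxy, and in this assay this alone gives a 5.8-fold lower number from compound 2 to compound 3 (0.77 log units; beyond the scatter). The far end of the side chain therefore affects the number, not only the group attached directly to the carbonyl carbon, and the whole replacement of (but-3-yn-1-yl)oxy with (carboxymethyl)(methyl)amino amounts to a 68-fold lower number from compound 1 to compound 3 (1.83 log units; beyond the scatter). Nothing available here explains this shift.

On these data alone, it remains open whether the carboxy group is needed as such, which a primary amide in its place would test, and whether carboxyethyl, a longer chain, would move the number further. As far as these compounds go, it is equally open whether an amine at the end of this chain would give a number closer to that of compound 2 or of compound 3.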